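The compounds below may be only part of what the source reports. "The series", "measured", "known", "first", "only" and "open" are said of these compounds alone.

In a functional assay on HT-1080 cells (Homo sapiens) for antiproliferative activity, read by MTT assay, with a stated time of 72 h (on this read-out lower numbers stand for stronger inhibition and higher numbers for weaker inhibition), compound 1 `COc1ccc(-c2sc(C(=O)O)cc2-c2cc(OC)c(OC)c(OC)c2)cc1` gives 6770 nM and compound 2 `COc1ccc(-c2sccc2-c2cc(OC)c(OC)c(OC)c2)cc1` gives 4590 nM. These two stand level, since a 1.5-fold lower number from compound 1 to compound 2 (0.17 log units; within the scatter) lies within the scatter and so says little here. Compound 3 `COc1cc(-c2ccsc2-c2cccc(Br)c2)cc(OC)c1OC` reaches only a limit of the assay, > 100000 nM. The step that bears most on what follows is the large one to that limit, an at least 21-fold higher number from compound 2 to compound 3 (1.33 log units; beyond the scatter), made by putting 3-bromophenyl in place of 4-methoxyphenyl. Compound 4 `COc1ccc(-c2sccc2-c2cc(OC)c(OC)c(OC)c2)cc1OCc1ccccc1` alters that same ring of compound 2: benzyloxy in place of hydrogen on an aromatic carbon, with benzyloxy in place of hydrogen, ortho to a methoxy group. The methoxy group stays, so a smaller rise in this assay is expected, an estimated 2.6-fold higher number from compound 2 to compound 4 (0.42 log units; beyond the scatter). The expected value for compound 4 is 12000 nM, within a range of 2500 nM to 60000 nM.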

Compound 4, half-maximal inhibitory concentration: > 100000 nM
Compound 4: only a limit was reported; the forecaster's own chance of this, stated with the estimate: 25%; middle value at least 8.3-fold (0.92 log units) away from the limit.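

In this assay, the methoxy group of compound 2 stays in place, yet adding benzyloxy ortho to it is enough for an at least 21-fold higher number from compound 2 to compound 4 (1.33 log units; beyond the scatter). The earlier loss came with replacing the whole 4-methoxyphenyl group, whereas here a single addition to that ring, with its methoxy group kept, already removes measurable activity. This step is only a minimum, as compound 4 sits at a limit of the assay rather than at a number: the limit of > 100000 nM in this assay, at which 2 of the 4 values shown sit.

As far as these compounds go, what a hydroxy group or an amine at this place would give remains open. The compounds shown also cannot tell why the activity is lost.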